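Removing the hydroxy group from compound 3

A few compounds are considered here, and "the series" means these few. Any claim that something is new, unique, unknown or untested is made for them only; others in the source may bear on it.

Measured in a functional assay on HepG2 cells (Homo sapiens) for inhibition, read by MTT assay, with a stated time of 72 h; a higher number here means a weaker inhibitor, a lower number a stronger inhibitor:
- compound 1 `O=[N+]([O-])c1ccc(-c2nnc(SCCCN3CCN(c4nc5ccccc5s4)CC3)o2)cc1`: 93300 nM
- compound 2 `Cc1ccc(-c2nnc(SCCCN3CCN(c4nc5ccccc5s4)CC3)o2)cc1`: 96700 nM
- compound 3 `Oc1ccc(-c2nnc(SCCCN3CCN(c4nc5ccccc5s4)CC3)o2)cc1`: 364000 nM

Compound 3 has the highest number of the three, and both steps to it lie beyond the scatter. Compound 4 `c1ccc(-c2nnc(SCCCN3CCN(c4nc5ccccc5s4)CC3)o2)cc1` has hydrogen in place of hydroxy on an aromatic carbon, 4-hydroxyphenyl to phenyl: hydrogen in place of hydroxy on an aromatic carbon.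

Among the compounds with values here, three measured steps bear on this change. Nitro and methyl give no separable values, with a 1.0-fold higher number from compound 1 to compound 2 (0.02 log units; within the scatter). Replacing either with hydroxy gives a modest rise, with a 3.9-fold higher number from compound 1 to compound 3 (0.59 log units; beyond the scatter) and a 3.8-fold higher number from compound 2 to compound 3 (0.58 log units; beyond the scatter). Within the data shown here, no compound with plain phenyl has been measured, so the return from hydroxy to hydrogen is an inference. On the evidence of these two hydroxy steps, a modest drop of similar size is expected in this assay, bringing the number near those of the nitro and methyl compounds.

The expected change is a 3.6-fold lower number from compound 3 to compound 4 (0.56 log units; beyond the scatter).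

For compound 4 the estimated value is 100000 nM, with an expected range of 45000 nM to 250000 nM.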

Compound 4, half-maximal inhibitory concentration: 217000 nM
For compound 4 the middle estimate is 2.2-fold (0.34 log units) below the measured one; the measured number falls inside the stated range.
By their numbers in this assay, from the lowest: compounds 1 and 2 (each within the scatter of the next); then compounds 4 and 3 (each within the scatter of the next).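

In this assay, hydrogen and hydroxy at this position on the phenyl ring are not separated (a 1.7-fold lower number from compound 3 to compound 4 (0.22 log units; within the scatter)), so the high number of compound 3 cannot be assigned to the hydroxy group itself. Hydrogen is instead separated from both other groups by modest steps (a 2.3-fold higher number from compound 1 to compound 4 (0.37 log units; beyond the scatter); a 2.2-fold higher number from compound 2 to compound 4 (0.35 log units; beyond the scatter)), which places nitro and methyl together at lower numbers and hydrogen and hydroxy together at higher ones, with no compound among the four going against this split. The available evidence offers no explanation for this grouping.

As far as these compounds go, it remains open whether an amine, a carboxylic acid or a chlorine atom at this position would fall with nitro and methyl or with hydrogen and hydroxy. From the compounds shown here alone, whether the same split appears in any other assay is also open.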